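The compounds below may be only part of what the source reports. "The series", "measured", "known", "first", "only" and "open" are said of these compounds alone.

Of the compounds shown here, three of a shared core have been tested in an ADME assay on HEL cells (Homo sapiens) for cytotoxicity, with a stated time of 3 days (on this read-out lower numbers stand for higher toxicity in this test and higher numbers for lower toxicity in this test), and a fourth awaits its number. Compound 3 `Cc1cn([C@@H]2O[C@H](CO[Si](C)(C)C(C)(C)C)[C@@]3(OS(=O)(=O)C=C3NC(=O)Nc3ccccc3)[C@H]2O[Si](C)(C)C(C)(C)C)c(=O)n(C)c1=O` gives 1400 nM in this assay, the lowest of the two plain numbers shown and a figure that stands clearly apart from compound 1 `Cc1cn([C@@H]2O[C@H](CO)[C@@]3(OS(=O)(=O)C=C3NC(=O)NC(=O)c3ccccc3)[C@H]2O[Si](C)(C)C(C)(C)C)c(=O)n(C)c1=O`, which gives 20000 nM. Compound 2 `Cc1cn([C@@H]2O[C@H](COCc3ccccc3)[C@@]3(OS(=O)(=O)C=C3NC(=O)NC(=O)c3ccccc3)[C@H]2O[Si](C)(C)C(C)(C)C)c(=O)n(C)c1=O` reaches only a limit of the assay, > 50000 nM, so no number is known for it (the limit of > 50000 nM in this assay, at which 1 of the 3 values shown sits). Within the data shown here, the one step that can be compared is an at least 2.5-fold higher number from compound 1 to compound 2 (0.39 log units; beyond the scatter), and it concerns a benzyl in place of hydrogen on an oxygen on a saturated carbon.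

Compound 4 `CCOC(=O)NC(=O)NC1=CS(=O)(=O)O[C@@]12[C@@H](CO[Si](C)(C)C(C)(C)C)O[C@@H](n1cc(C)c(=O)n(C)c1=O)[C@@H]2O[Si](C)(C)C(C)(C)C` differs from compound 3 in a single place: ethoxycarbonyl in place of phenyl on an amide-type nitrogen. Among the measured compounds shown here, no measured step touches this kind of change, so the comparison of compound 1 with compound 3 is the only guide, and those two differ in more than one place. Compound 1, which carries a benzoylcarbamoyl group, gives a far higher number than compound 3 with its phenylcarbamoyl group, and compound 4 carries an ethoxycarbonylcarbamoyl group of the same acyl-urea kind. The expectation is therefore a modest rise, a 3.6-fold higher number from compound 3 to compound 4 (0.55 log units; beyond the scatter), though with wide uncertainty. Compound 4 is estimated at 5000 nM, between 1400 nM and 50000 nM.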

Compound 4, minimum cytotoxic concentration: 10000 nM
Compound 4: the middle estimate sits 2.0-fold (0.30 log units) below what was measured; the measured number falls inside the stated range.
By their numbers in this assay, from the lowest: compound 3; then compounds 4 and 1 (each within the scatter of the next). At a limit, above all of these: compound 2.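

In this assay, among these compounds, swapping phenyl for ethoxycarbonyl on the amide-type nitrogen gives a 7.1-fold higher number from compound 3 to compound 4 (0.85 log units; beyond the scatter), and this is the first reading at this position with the rest of the molecule unchanged. It shows that this one group can by itself move the number beyond the scatter, with lower toxicity in this test when an aromatic ring of carbon only gives way to an open group with no ring that carries hydrogen-bond acceptors; the earlier step concerned a different place, an oxygen on a saturated carbon. Nothing measured on these compounds explains the rise.

This single change removes the ring and brings in a carbonyl and an ethyl ester oxygen at once, so the compounds shown do not tell which of these matters. On these data alone, a cyclohexyl group or a plain ethyl chain on the same nitrogen, with the rest of compound 3 kept, would begin to separate the loss of the aromatic ring from the gain of the ester, and it remains open whether either would land nearer compound 3 or compound 4.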